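The source may hold more compounds than are shown below. What is called first, only, known or untested is meant among the compounds shown, and "the series" means these compounds.

Measured compounds: compound 1 `COC(=O)c1ccc(N(Cc2ccc(C3CCCCC3)cn2)C(=O)[C@H]2CCN2S(=O)(=O)c2c(F)c(F)c(F)c(F)c2F)cc1O` at 1800 nM; compound 2 `COC(=O)c1ccc(N(Cc2cnc(C3CCCCC3)cn2)C(=O)[C@H]2CCN2S(=O)(=O)c2c(F)c(F)c(F)c(F)c2F)cc1O` at 1600 nM; compound 3 `O=C([C@H]1CCN1S(=O)(=O)c1c(F)c(F)c(F)c(F)c1F)N(Cc1ccc(C2CCCCC2)cn1)c1cc2[nH]ncc2cc1F` at 2300 nM, all in a functional assay on MDA-MB-231 cells (Homo sapiens) for antiproliferative activity, with a stated time of 72 h; a lower number here means that less compound is needed, a higher number that more compound is needed for the effect.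

Compound 4 `O=C([C@H]1CCN1S(=O)(=O)c1c(F)c(F)c(F)c(F)c1F)N(Cc1cnc(C2CCCCC2)cn1)c1cc2[nH]ncc2cc1F` is not yet measured. The cores of compound 1 and compound 3 differ in this way: 5-fluoro-1H-indazol-6-yl in place of 3-hydroxy-4-(methoxycarbonyl)phenyl on an amide-type nitrogen, and in this assay that difference gave a 1.3-fold higher number from compound 1 to compound 3 (0.11 log units; within the scatter). The change from compound 3 to compound 4 is 5-cyclohexylpyrazin-2-yl in place of 5-cyclohexylpyridin-2-yl on a saturated chain carbon bound to an amide-type nitrogen. The same change has already been made once, between compound 1 and compound 2, where it is 5-cyclohexylpyrazin-2-yl in place of 5-cyclohexylpyridin-2-yl on a saturated chain carbon bound to an amide-type nitrogen and gave a 1.1-fold lower number from compound 1 to compound 2 (0.05 log units; within the scatter). Since the place of the change is the same in both pairs, and since compound 1 reads close to compound 3 with 2300 nM, compound 4 is expected to show a step of about a 1.1-fold lower number from compound 3 to compound 4 (0.04 log units; within the scatter). Compound 4 is therefore estimated at 2100 nM, with a range from 1000 nM to 4500 nM.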

Compound 4, half-maximal effective concentration: 2000 nM
The estimate for compound 4 lay 1.1-fold (0.02 log units) above the measured number; the range from low to high includes it.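

In this assay 5-cyclohexylpyrazin-2-yl in place of 5-cyclohexylpyridin-2-yl gave a 1.2-fold lower number from compound 3 to compound 4 (0.06 log units; within the scatter) and so read on the second core as on the first: the same change on two cores in this assay, a 1.1-fold lower number (0.05 log units; within the scatter) from compound 1 to compound 2 and a 1.2-fold lower number (0.06 log units; within the scatter) from compound 3 to compound 4, 1.0-fold (0.01 log units) apart, within the scatter of two such steps.
The core change read alike on both side groups, with a 1.3-fold higher number from compound 2 to compound 4 (0.10 log units; within the scatter) set against the earlier step: the same change on two cores in this assay, a 1.3-fold higher number (0.11 log units; within the scatter) from compound 1 to compound 3 and a 1.3-fold higher number (0.10 log units; within the scatter) from compound 2 to compound 4, 1.0-fold (0.01 log units) apart, within the scatter of two such steps.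
Going by these compounds alone, both changes thus carried over between these two cores, but every step lies within the scatter, so this shows only that neither change moved the number measurably here, not that a larger effect would transfer or that other cores would behave alike.

The compounds shown leave open whether the pattern survives with an amine such as piperidine or a short chain such as ethyl in place of cyclohexyl. They also leave open what a carboxylic acid in place of the methoxycarbonyl group would do.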